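This account rests on a few compounds, and the source may have more. Where it says the series, first, only, none or still open, it means among the compounds named here.

Measured compounds:
Compound 1 `C[C@H](NC(=O)C(=O)Nc1ccccc1Cl)C(=O)N[C@@H](CC(=O)O)C(=O)COc1c(F)c(F)cc(F)c1F` gives 64 nM.
Compound 2 `C[C@H](NC(=O)C(=O)Nc1ccccc1Br)C(=O)N[C@@H](CC(=O)O)C(=O)COc1c(F)c(F)cc(F)c1F` gives 75 nM.

Both of these compounds share one core and differ only in a single group on an aromatic carbon of a six-membered aromatic ring of carbon only. In a functional assay on Jurkat cells (Homo sapiens) for inhibition (on this read-out higher numbers stand for weaker inhibition and lower numbers for stronger inhibition), compound 2 stands with the highest of the two numbers, but its distance from compound 1 is small: the step of a 1.2-fold higher number from compound 1 to compound 2 (0.07 log units; within the scatter) lies within the scatter, so the two compounds cannot be told apart on this read-out.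

Compound 3 `C[C@H](NC(=O)C(=O)Nc1ccccc1Cc1ccccc1)C(=O)N[C@@H](CC(=O)O)C(=O)COc1c(F)c(F)cc(F)c1F` has not been measured. It follows from compound 2 by the change (benzyl in place of bromo on an aromatic carbon), at the position ortho to a large group. Among the measured compounds shown here, only the one measured step bears on this change, and it shows that exchanging one halogen for another at this position leaves the number where it was. For the measured compounds named here, a benzyl group is a much larger substituent than either halogen, and nothing among the measured compounds tells how such a group behaves here. The expectation for compound 3 in this assay is therefore cautious: a step of a 1.6-fold higher number from compound 2 to compound 3 (0.20 log units; within the scatter), most likely small, with a wide range to allow for a larger shift in either direction. Compound 3 is estimated at 120 nM, between 35 nM and 500 nM.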

Compound 3, half-maximal inhibitory concentration: 10 nM
The estimate for compound 3 lay 12-fold (1.08 log units) above the measured number; the measured number lies below the stated range.
By their numbers in this assay, from the lowest: compound 3; then compounds 1 and 2 (each within the scatter of the next).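

In this assay the earlier exchange of one halogen for another left the number where it was, so it said little about what a much larger group would do on this aromatic carbon, ortho to a large group. Benzyl, with 7 heavy atoms and a ring of its own, gives a clear rise in inhibition over bromo, with a 7.5-fold lower number from compound 2 to compound 3 (0.88 log units; beyond the scatter), and also over chloro, with a 6.4-fold lower number from compound 1 to compound 3 (0.81 log units; beyond the scatter), which makes compound 3 the strongest inhibitor of the three on this read-out. This position therefore accepts far more than a single halogen atom and can respond strongly to the group placed there, although nothing available explains the change.

The compounds shown leave open whether a phenyl group attached directly to this carbon, or a longer chain such as phenylethyl, would give a similar step. They also leave open whether the added ring of benzyl can carry further groups, such as an amine or a carboxylic acid, without losing the lower number.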